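The source may hold more compounds than are shown below. What is called first, only, known or untested is meant among the compounds shown, and "the series" means these compounds.

Three compounds have been measured in an assay on HEK293 cells for agonist activity at transient receptor potential cation channel subfamily M member 8 (Homo sapiens), read by fluorescence and calcium flux, with a stated time of 15 min; a lower number here means that less compound is needed, a higher number that more compound is needed for the effect:
compound 1, `CCN(Cc1cccs1)C(=O)C(C)Oc1ccc(C)cc1`, gives 889 nM;
compound 2, `CCC(C)N(Cc1cccs1)C(=O)COc1ccc(C)cc1`, gives 2000 nM;
compound 3, `Cc1ccc(OCC(=O)N(Cc2cccs2)C(C)C)cc1`, gives 70 nM.

Compound 3 and compound 2 differ in one place: methyl in place of hydrogen on a saturated chain carbon, two bonds along the chain from an amide-type nitrogen. That single change made a large step in this assay, a 29-fold higher number from compound 3 to compound 2 (1.46 log units; beyond the scatter). Compound 1 has the same atoms as compound 3, joined differently; the difference between their two cores is not broken down here. Compound 4, `CCN(Cc1cccs1)C(=O)C(C)(C)Oc1ccc(C)cc1`, has not yet been measured. It differs from compound 1 by methyl in place of hydrogen on a saturated chain carbon bound to a carbonyl carbon, an oxygen on an aromatic ring and a saturated chain carbon. This is the same kind of change as that from compound 3 to compound 2, but not the same: there the methyl enters on a saturated chain carbon, two bonds along the chain from an amide-type nitrogen, here on a saturated chain carbon bound to a carbonyl carbon, an oxygen on an aromatic ring and a saturated chain carbon. Because the earlier methyl produced a 29-fold higher number from compound 3 to compound 2 (1.46 log units; beyond the scatter), a step in the same direction is expected, a 4.5-fold higher number from compound 1 to compound 4 (0.65 log units; beyond the scatter), though a smaller one, since the place differs. Compound 4 is therefore estimated at 4000 nM, with a likely range from 1500 nM to 12000 nM.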

Compound 4, half-maximal effective concentration: 11000 nM
Estimate against measurement, compound 4: 2.8-fold (0.44 log units) below; the range from low to high includes it.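

On the core of compound 1, adding a single methyl again makes a large difference in this assay, with a 12-fold higher number from compound 1 to compound 4 (1.09 log units; beyond the scatter). The earlier methyl step points the same way, and the two steps cannot be told apart in size, even though the methyl enters at a different place in each pair: the same change on two cores in this assay, a 29-fold higher number (1.46 log units; beyond the scatter) from compound 3 to compound 2 and a 12-fold higher number (1.09 log units; beyond the scatter) from compound 1 to compound 4, 2.3-fold (0.36 log units) apart, within the scatter of two such steps

This shows that the change carried over between these two cores in direction and in rough size, with more compound needed each time, but two pairs do not establish a rule for every core or every saturated chain carbon in the series, and these numbers do not explain why the methyl has this effect. The compounds shown leave open whether a longer chain, such as ethyl, or a different group, such as a hydroxyl group or an amine, on the same saturated chain carbon would raise the number as methyl does.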